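This account rests on a few compounds, and the source may have more. Where it says the series, first, only, none or still open, it means among the compounds named here.

Compound 1: `Nc1ccccc1NC(=O)c1ccc(COc2ccc(Cl)cc2)cc1` — > 32000 nM
Compound 2: `Nc1ccccc1NC(=O)c1ccc(COc2ccccc2)cc1` — 5670 nM

In a functional assay on MGC-803 cells (Homo sapiens) for antiproliferative activity, read by CCK-8 assay, with a stated time of 72 h (on this read-out lower numbers stand for stronger inhibition and higher numbers for weaker inhibition), compound 1 gives > 32000 nM, which is a limit of the assay rather than a number (the limit of > 32000 nM in this assay, at which 1 of the 2 values shown sits). Compound 2 gives 5670 nM, the only plain number shown, so it stands alone. Compound 3, `COc1ccc(OCc2ccc(C(=O)Nc3ccccc3N)cc2)cc1`, is not yet measured; its change from compound 2 is methoxy in place of hydrogen on an aromatic carbon. Going by the values given here, the one measured step, an at least 5.6-fold lower number from compound 1 to compound 2 (0.75 log units; beyond the scatter), concerns the same place on the ring and shows that a chloro there weakens inhibition. A methoxy entering there is expected to shift the number by a 1.6-fold higher number from compound 2 to compound 3 (0.20 log units; within the scatter). Compound 3 is therefore expected to give 9000 nM, within 2500 nM to 32000 nM.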

Compound 3, half-maximal inhibitory concentration: 3480 nM
The estimate for compound 3 lay 2.6-fold (0.41 log units) above the measured number; low and high end bracket the measured number.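

Methoxy in place of hydrogen gives a 1.6-fold lower number from compound 2 to compound 3 (0.21 log units; within the scatter), so the two cannot be told apart, and a group at this place, para to a large group, need not weaken inhibition. Methoxy in place of chloro gives an at least 9.1-fold lower number from compound 1 to compound 3 (0.96 log units; beyond the scatter), so the weakening seen with chloro does not extend to every group here. Compound 1 stands at a limit of the assay, not at a number: the limit of > 32000 nM in this assay, at which 1 of the 3 values shown sits.

From the compounds shown here alone, how an amine, a carboxylic acid or a longer chain would behave at this place stays open. So does whether any group here can lower the number beyond the scatter.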